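Replacing 4-hydroxycyclohexyl with 3,4-dinitrophenyl on compound 1

This account rests on a few compounds, and the source may have more. Where it says the series, first, only, none or still open, it means among the compounds named here.

For the measured compounds named here, in an ADME assay on HEK-293T cells (Homo sapiens) for cytotoxicity, read by CCK-8 assay, with a stated time of 48 h (on this read-out higher numbers stand for weaker inhibition and lower numbers for stronger inhibition), compound 1 `O=C(NCCNS(=O)(=O)c1ccc(-c2ccccc2O[C@H]2CC[C@@H](O)CC2)s1)Nc1ccc([N+](=O)[O-])cc1` gives 8600 nM, the lower of the two numbers so far. Compound 2 `O=[N+]([O-])c1ccc(NC(=S)NCCNS(=O)(=O)c2ccc(-c3ccccc3O[C@H]3CC[C@@H](O)CC3)s2)cc1` gives 20000 nM. Compound 3 `O=C(NCCNS(=O)(=O)c1ccc(-c2ccccc2Oc2ccc([N+](=O)[O-])c([N+](=O)[O-])c2)s1)Nc1ccc([N+](=O)[O-])cc1` has 3,4-dinitrophenyl in place of 4-hydroxycyclohexyl on an oxygen on an aromatic ring. Going by the values given here, the only measured step, a 2.3-fold higher number from compound 1 to compound 2 (0.37 log units; beyond the scatter), is a modest one on an amine nitrogen, so it bears on this change only indirectly. Among the compounds with values here, no step at this oxygen has been measured. In this assay, the expected change is a 1.2-fold lower number from compound 1 to compound 3 (0.09 log units; within the scatter), which is none beyond the scatter. For compound 3, the estimated value is 7000 nM, with an expected range from 2500 nM to 20000 nM.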

Compound 3, half-maximal inhibitory concentration: 16600 nM
Estimate against measurement, compound 3: 2.4-fold (0.38 log units) below; the range from low to high includes it.
By their numbers in this assay, from the lowest: compounds 1, 3 and 2 (each within the scatter of the next, the first and the last beyond it).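

In this assay, the first step measured at this oxygen, with 3,4-dinitrophenyl in place of 4-hydroxycyclohexyl, gives a 1.9-fold higher number from compound 1 to compound 3 (0.29 log units; within the scatter) and so stays within the usual scatter. The change goes from a non-aromatic ring to an aromatic one, yet the read-out does not separate the two compounds. Nothing measured here accounts for this result. Still open, on these data alone, is whether a smaller group on this oxygen, such as a plain phenyl, a methyl or a chain ending in an amine or a carboxylic acid, would move the number beyond the scatter.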